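Notes on sulfonyl variation in the aryl-alkyne series

The source may hold more compounds than are shown below. What is called first, only, known or untested is meant among the compounds shown, and "the series" means these compounds.

Measured compounds:
Compound 1 `Cc1ccc(S(=O)(=O)Cc2ccccc2)cc1C#Cc1cc(Cl)ccc1OCC(=O)O`: 5 nM
Compound 2 `O=C(O)COc1ccc(Cl)cc1C#Cc1cc(CO)ccc1F`: 73 nM
Compound 3 `Cc1ccc(S(=O)(=O)CCO)cc1C#Cc1cc(Cl)ccc1OCC(=O)O`: 19 nM

All three values come from an assay on CHO cells for displacement of a labelled ligand from prostaglandin D2 receptor 2 (Homo sapiens), read by scintillation counting; a lower number here means a stronger inhibitor, a higher number a weaker inhibitor. Compound 3 stands second highest of the three numbers: compound 1 sits at the lower end, compound 2 at the higher end, each separated from compound 3 by a gap that the scatter does not cover. Among the compounds with values here, the one step that touches compound 3 directly is the exchange on the sulfonyl sulfur, a 3.8-fold higher number from compound 1 to compound 3 (0.58 log units; beyond the scatter).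

Compound 4 `Cc1ccc(S(=O)(=O)N(C)CCN(C)C)cc1C#Cc1cc(Cl)ccc1OCC(=O)O` differs from compound 3 at the same sulfonyl sulfur: (2-(dimethylamino)ethyl)(methyl)amino in place of 2-hydroxyethyl on a sulfonyl sulfur. The step from compound 1 to compound 3 bears on this because a 3.8-fold higher number from compound 1 to compound 3 (0.58 log units; beyond the scatter) shows that the group on this sulfur moves the number by a modest amount. Within the data shown here, no measured step covers an amino group in this place, and compound 2 carries a different substitution pattern altogether, so its value only marks the upper end of the range seen. A modest shift in either direction would not be surprising; the expectation is a step near the scatter, a 1.3-fold higher number from compound 3 to compound 4 (0.12 log units; within the scatter). Compound 4 is therefore estimated at 25 nM, with a range of 8 nM to 80 nM.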

Compound 4, inhibition constant: 369 nM
Compound 4: the middle estimate sits 15-fold (1.17 log units) below what was measured; the measured number lies above the stated range.
By their numbers in this assay, from the lowest: compound 1; then compound 3; then compound 2; then compound 4.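

The group on the sulfonyl sulfur can move the number much further than the benzyl to 2-hydroxyethyl exchange suggested: (2-(dimethylamino)ethyl)(methyl)amino gives a 19-fold higher number from compound 3 to compound 4 (1.29 log units; beyond the scatter), a large step against the modest one seen before. Measured against the benzyl group, the same group gives a 74-fold higher number from compound 1 to compound 4 (1.87 log units; beyond the scatter), so this position tolerates some groups far better than others. Nothing available accounts for the size of these steps.

The change from 2-hydroxyethyl replaces the atom bound to sulfur, the chain and its end group together, and the compounds shown do not separate these parts. A 2-(dimethylamino)ethyl group bound to sulfur through carbon, or a 2-hydroxyethylamino group, would each change only part of this difference and show which part carries the step.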